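Swapping an ethyl group for hydrogen on a ring carbon

The source may hold more compounds than are shown below. What is called first, only, known or untested is meant among the compounds shown, and "the series" means these compounds.

In a functional assay on HL-60 cells (Homo sapiens) for antiproliferative activity, read by MTT assay (a lower number here means a stronger inhibitor, a higher number a weaker inhibitor), compound 2 (`CC[C@@H]1O[C@H](COCc2ccccc2)[C@@H](OCc2ccccc2)[C@H](OCc2ccccc2)[C@H]1O`) gives 8200 nM as its reading. Compound 1 (`CC(C)(C)C[C@H]1O[C@H](COCc2ccccc2)[C@@H](OCc2ccccc2)[C@H](OCc2ccccc2)[C@H]1O`) gives 12100 nM as its reading and carries a different chain on the same ring carbon. These two numbers lie within the usual scatter of repeated measurements, so the data do not separate the two compounds, and compound 2 stands level with compound 1.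

Compound 3 (`O[C@H]1CO[C@H](COCc2ccccc2)[C@@H](OCc2ccccc2)[C@@H]1OCc1ccccc1`) has hydrogen in place of ethyl on a saturated ring carbon and so has no chain there at all. Within the data shown here, no measured compound yet shows what this loss does, which makes any forecast a cautious one. Among the measured compounds shown here, the only guide is that compound 1 at 12100 nM and compound 2 at 8200 nM agree within the scatter despite their different chains. On that thin basis, the expected change is a 1.2-fold higher number from compound 2 to compound 3 (0.09 log units; within the scatter) in this assay and should stay within the scatter. The estimate for compound 3 is 10000 nM with a range from 4000 nM to 25000 nM as the expected span of a measurement.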

Compound 3, half-maximal inhibitory concentration: "not active" (no number reported)
The entry for compound 3 holds no number; there is nothing to compare the estimate with.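

Among these compounds, compound 3 is entered as "not active" with no number in this assay, so no step from compound 2 to compound 3 can be read. The compounds shown leave open how much the reading changes when hydrogen replaces ethyl on this ring carbon. Nothing measured here accounts for the "not active" entry.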